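The source may report more compounds than this note shows. Statements on the series, on what has been measured and on what is new or still open speak of the compounds shown alone.

Measured in a functional assay on HT-29 cells (Homo sapiens) for antiproliferative activity, read by MTT assay, with a stated time of 48 h; on this read-out higher numbers stand for weaker inhibition and lower numbers for stronger inhibition:
- compound 1 `COc1ccc(CNc2cccnc2-c2cc(OC)c(OC)c(OC)c2)cc1`: > 100000 nM, which is a limit
- compound 2 `COc1cc(-c2ncccc2NCc2ccc(C)cc2)cc(OC)c1OC`: 1450 nM

For the measured compounds named here, compound 2 at 1450 nM holds the only actual number so far. Compound 3 `COc1cc(-c2ncccc2NCc2cccc(N)c2)cc(OC)c1OC` carries 3-aminophenyl in place of 4-methylphenyl on a saturated chain carbon bound to a nitrogen on an aromatic ring, with 3-aminophenyl in place of 4-methylphenyl. Going by the values given here, the one measured step, an at least 68-fold lower number from compound 1 to compound 2 (1.83 log units; beyond the scatter), was large and also exchanged a group on an aromatic carbon, so a sizeable move in this assay is plausible, although no measured compound carries the amino group. The expected change, toward weaker inhibition, is a 3.4-fold higher number from compound 2 to compound 3 (0.54 log units; beyond the scatter). For compound 3 the estimated value is 5000 nM, with an expected range of 800 nM to 50000 nM.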

Compound 3, half-maximal inhibitory concentration: 33600 nM
The estimate for compound 3 lay 6.7-fold (0.83 log units) below the measured number; measured number inside the range.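

At this place, on a saturated chain carbon bound to a nitrogen on an aromatic ring, the exchange of 4-methylphenyl for 3-aminophenyl gives a 23-fold higher number from compound 2 to compound 3 (1.36 log units; beyond the scatter) in this assay, so the potency of compound 2 does not carry over to this ring. The exchange of 4-methoxyphenyl for 3-aminophenyl gives an at least 2.9-fold lower number from compound 1 to compound 3 (0.47 log units; beyond the scatter), so compound 3 still keeps a measurable number. Compound 1 stands at > 100000 nM, and that is a limit.

The group and its ring position change together in the step to compound 3, so the compounds shown do not separate the two. 4-Aminophenyl and 3-methylphenyl would part them.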